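Extending the Chain: From Compound 2 to Compound 3

The source may report more compounds than this note shows. Statements on the series, on what has been measured and on what is new or still open speak of the compounds shown alone.

Compound 1 `COc1cc(-c2noc(-c3ccc(NC(=O)OC(C)(C)C)cc3)n2)cc(OC)c1OC` gives 9200 nM in an ADME assay on cells (Splenocyte, Mus musculus, strain BALB/c) for cytotoxicity, read by CCK-8 assay, with a stated time of 48 h; a lower number here means that less compound is tolerated, a higher number that more compound is tolerated. Compound 2 `CCc1ccc(-c2nc(-c3cc(OC)c(OC)c(OC)c3)no2)cc1` gives 31300 nM, the higher of the two numbers, separated from compound 1 by a 3.4-fold higher number from compound 1 to compound 2 (0.53 log units; beyond the scatter). Compound 3 `CCCCCCc1ccc(-c2nc(-c3cc(OC)c(OC)c(OC)c3)no2)cc1` differs from compound 2 by butyl in place of hydrogen on a saturated chain carbon, two bonds along the chain from an aromatic carbon. For the measured compounds named here, the only measured step swaps a whole group on the ring rather than lengthening a chain, so it bears little on this change, and no step beyond the scatter is expected. Compound 3 is therefore estimated to give 25000 nM, between 8000 nM and 80000 nM, a step of a 1.3-fold lower number from compound 2 to compound 3 (0.10 log units; within the scatter).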

Compound 3, half-maximal cytotoxic concentration: 25000 nM
For compound 3 middle estimate and measured number coincide at the digits printed, within the range that was stated.
By their numbers in this assay, from the lowest: compound 1; then compounds 3 and 2 (each within the scatter of the next).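

In this assay lengthening ethyl to hexyl gives a 1.3-fold lower number from compound 2 to compound 3 (0.10 log units; within the scatter) and so leaves the number within the usual scatter: this chain carbon takes on butyl with no readable change. Replacing the (tert-butoxycarbonyl)amino group with hexyl gives a 2.7-fold higher number from compound 1 to compound 3 (0.43 log units; beyond the scatter) and so stays beyond the scatter, which means the higher number seen with ethyl holds for the longer chain too. No measured evidence explains either step. Still open, as far as these compounds go, is how a chain ending in an amine or a carboxylic acid would fare here.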